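The source may hold more compounds than are shown below. What is called first, only, known or untested is meant among the compounds shown, and "the series" means these compounds.

Compound 1, `Cc1ccc(S(=O)(=O)c2cnc3cc(F)ccc3c2N2CCC(C)CC2)cc1C`, gives 90%.
Compound 2, `CC1CCN(c2c(S(=O)(=O)c3ccc(F)c(Cl)c3)cnc3cc(F)ccc23)CC1`, gives 94%.
Compound 3, `Cc1ccc2ncc(S(=O)(=O)c3ccc(C)c(C)c3)c(N3CCC(C)CC3)c2c1`, gives 90%.

These three compounds were tested in an assay on isolated protein for displacement of a labelled ligand from metabotropic glutamate receptor 5 (Homo sapiens), with a stated time of 60 min, tested at 1 uM; on this read-out higher numbers stand for more inhibition at the one concentration tested (going by the name of the read-out) and lower numbers for less inhibition. Compound 1 and compound 2 share one core and differ in a single place: 3-chloro-4-fluorophenyl in place of 3,4-dimethylphenyl on a sulfonyl sulfur. That change made a step of a number 4 percentage points higher from compound 1 to compound 2 (within the scatter), which is a small difference and lies within the usual spread of repeated measurements, so the two compounds read as level.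

Compound 3 carries a different core from compound 1; the difference between the two cores is not broken down here. In this assay compound 3 gives 90%, which is level with compound 1 at the digits reported and sits within the spread of both compound 1 and compound 2.

Compound 4, `Cc1ccc2ncc(S(=O)(=O)c3ccc(F)c(Cl)c3)c(N3CCC(C)CC3)c2c1`, has not yet been measured. It differs from compound 3 by 3-chloro-4-fluorophenyl in place of 3,4-dimethylphenyl on a sulfonyl sulfur, the same change that separates compound 1 from compound 2. Because the earlier step was a number 4 percentage points higher from compound 1 to compound 2 (within the scatter), the change is expected to move the number only a little on the new core as well. The step from compound 3 to compound 4 is therefore estimated at a number 3 percentage points higher from compound 3 to compound 4 (within the scatter). For compound 4 in this assay the estimate is 93%, expected to fall between 84% and 99%.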

Compound 4, a percentage reported as inhibition, at one concentration (the size of the read-out at that concentration, not a potency): 93%
The estimate for compound 4 equals the measured number at the digits printed; low and high end bracket the measured number.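

In this assay, the same change on the sulfonyl sulfur, made this time on the second core, gives a number 3 percentage points higher from compound 3 to compound 4 (within the scatter). Set beside the earlier case, the change reads alike on both cores: the same change on two cores in this assay, a number 4 percentage points higher (within the scatter) from compound 1 to compound 2 and a number 3 percentage points higher (within the scatter) from compound 3 to compound 4, 1 percentage points apart, within the scatter of two such steps. This shows that the change can be carried from one of these cores to the other without moving the reading beyond ordinary spread, but it does not show a real gain on either core, and two cores say nothing certain about further ones; a reading at one concentration also gives the size of the inhibition there, not a potency, so any difference in potency between these compounds stays hidden.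

Only two groups appear on the sulfonyl sulfur in the compounds shown, so it remains open how the reading would respond to an aromatic ring carrying an amine or a carboxylic acid, or to a longer chain in place of that ring. Also open, going by these compounds, is whether the amine-linked ring on the core, the same in all four compounds, can be replaced by an open-chain amine while the reading holds.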